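The source may report more compounds than this note shows. Statements on the series, on what has been measured and on what is new or still open speak of the compounds shown alone.

Compound 1 `COc1ccc(-c2nc3cc(F)ccc3s2)cc1Cl` gives 480 nM in a functional assay on MDA-MB-468 cells (Homo sapiens) for antiproliferative activity; a higher number here means a weaker inhibitor of growth, a lower number a stronger inhibitor of growth.
Compound 2 `COc1ccc(-c2nc3cc(F)ccc3s2)cc1I` gives 360 nM in this assay.

Compound 2 has the lowest of the two numbers, yet compound 1 lies within the scatter of it. Compound 3 `COc1ccc(-c2nc3cc(F)ccc3s2)cc1O` differs from compound 2 by hydroxy in place of iodo on an aromatic carbon. Among the measured compounds shown here, the only measured step, a 1.3-fold lower number from compound 1 to compound 2 (0.12 log units; within the scatter), exchanges one halogen for another and stays within the scatter; no measured step exchanges a halogen for a hydroxy group, so the change to compound 3 has no direct precedent here. The estimate for compound 3 in this assay is 800 nM, with a range from 250 nM to 3000 nM, which means an expected step of a 2.2-fold higher number from compound 2 to compound 3 (0.35 log units; beyond the scatter).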

Compound 3, concentration for 50% growth inhibition: 50 nM
Compound 3: middle estimate off by 16-fold (1.20 log units), on the high side; measured number outside the range, below it.
By their numbers in this assay, from the lowest: compound 3; then compounds 2 and 1 (each within the scatter of the next).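

In this assay this aromatic carbon, ortho to a methoxy group, proved sensitive to its substituent: hydroxy gives a 7.2-fold lower number from compound 2 to compound 3 (0.86 log units; beyond the scatter) and also a 9.6-fold lower number from compound 1 to compound 3 (0.98 log units; beyond the scatter) in the same direction. Exchanging one halogen for another had not revealed this sensitivity. The data offer no evidence for why hydroxy has this effect.

The compounds shown leave open whether the lower number is specific to hydroxy or extends to other groups at this position, such as an amine or a carboxylic acid.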